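The compounds below may be only part of what the source reports. "The series", "measured", "known", "first", "only" and "open" are said of these compounds alone.

Within the data shown here, compound 2 `COc1cccc(Sc2c(NS(=O)(=O)c3ccc(C(C)(C)C)cc3)noc2CCO)c1` gives the higher of the two numbers measured so far in an assay on COS-7 cells for displacement of a labelled ligand from Endothelin receptor type B (Sus scrofa) (a lower number here means a stronger inhibitor, a higher number a weaker inhibitor), with 430 nM; compound 1 `COc1cccc(Sc2c(NS(=O)(=O)c3ccc(C(C)(C)C)cc3)noc2CCC/C=N/O)c1` gives 85 nM. Among the measured compounds shown here, the only step bearing on the present change, a 5.1-fold higher number from compound 1 to compound 2 (0.70 log units; beyond the scatter), came from cutting the chain on the shared core down to a hydroxyethyl group. Compound 3 `COc1cccc(Sc2c(NS(=O)(=O)c3ccc(C(C)(C)C)cc3)noc2CO)c1` carries hydroxy in place of hydroxymethyl on a saturated chain carbon bound to an aromatic carbon, shortening that chain once more. For the measured compounds named here, as the first shortening raised the number beyond the scatter, a further rise is expected here, a 2.6-fold higher number from compound 2 to compound 3 (0.41 log units; beyond the scatter), though with much uncertainty from a single step. Compound 3 is therefore estimated at 1100 nM, between 350 nM and 3500 nM.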

Compound 3, half-maximal inhibitory concentration: 560 nM
Beside the measured number, compound 3's estimate is 2.0-fold (0.29 log units) above it; the measured number falls inside the stated range.
By their numbers in this assay, from the lowest: compound 1; then compounds 2 and 3 (each within the scatter of the next).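

In this assay taking the chain from 2-hydroxyethyl to hydroxymethyl gives a 1.3-fold higher number from compound 2 to compound 3 (0.11 log units; within the scatter) and so shows no clear difference between these two short chains. Cutting the full chain of compound 1 back to hydroxymethyl gives a 6.6-fold higher number from compound 1 to compound 3 (0.82 log units; beyond the scatter) and so stays clearly apart from them. Nothing measured here explains these numbers.

Still open, from the compounds shown here alone, is whether the hydroxy end of the short chains matters at all, or whether an amine or a carboxylic acid there would give a different number. Also open, going by these compounds, is which part of the longer chain of compound 1 goes with its lower number.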